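Shortening the alkyl chain of compound 1

A few compounds are considered here, and "the series" means these few. Any claim that something is new, unique, unknown or untested is made for them only; others in the source may bear on it.

Going by the values given here, compound 1 `CCCCCNNC(=O)c1ccc(-c2ccc(CNC(C)=O)cc2)cc1` is the weakest of the three measured members of this set. In an assay on isolated protein for inhibition of histone deacetylase 8 (Homo sapiens), read by fluorescence, with a stated time of 5 min (a lower number here means a stronger inhibitor, a higher number a weaker inhibitor), compound 1 gives 350 nM. Compound 2 `CCCCCCNNC(=O)c1cccc(NCc2ccccc2)c1` carries a different core and a chain one carbon longer; in this assay compound 2 gives 46 nM. Compound 3 `CCCCCCNNC(=O)c1cnc(NCc2ccc(CNC(C)=O)cc2)nc1` also carries a longer chain on another core, and in this assay compound 3 gives 19 nM. Among the compounds with values here, both gaps from compound 1 lie beyond the scatter, so compound 1 stands clearly behind the two longer-chain compounds, though the core differs as well, and no single-point step is available to separate the two effects.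

Compound 4 `CCCCNNC(=O)c1ccc(-c2ccc(CNC(C)=O)cc2)cc1` keeps the core of compound 1 and differs only in the chain: hydrogen in place of methyl on a saturated chain carbon, four bonds along the chain from an amine nitrogen. Within the data shown here, no measured pair in the set isolates this change. The measured numbers show only that the two longer chains sit with lower values, which gives a weak hint that a shorter chain goes the other way; a step from compound 1 to compound 4 of modest size toward a higher number is therefore expected, a 2.0-fold higher number from compound 1 to compound 4 (0.30 log units; within the scatter), with the possibility that it stays within the scatter. For compound 4 in this assay the estimate is 700 nM, in the range 250 nM to 2500 nM.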

Compound 4, half-maximal inhibitory concentration: 360 nM
Compound 4: middle estimate off by 1.9-fold (0.29 log units), on the high side; the range from low to high includes it.
By their numbers in this assay, from the lowest: compound 3; then compound 2; then compounds 1 and 4 (each within the scatter of the next).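

Going by these compounds alone, on the core of compound 1, hydrogen in place of methyl on a saturated chain carbon, four bonds along the chain from an amine nitrogen, gives a 1.0-fold higher number from compound 1 to compound 4 (0.01 log units; within the scatter) in this assay and is the first step that separates a chain change from a core change. At this position and on this core, removing one carbon therefore produces no change that can be told from the scatter, so the earlier hint from compounds with different cores finds no support in this direct comparison. Nothing at hand bears on the origin of this result.

Within the data shown here, this single step covers only one chain length on one core, so it remains open whether a much shorter chain such as ethyl, or a longer chain such as heptyl, would hold the same level on the core of compound 1. Also open, on these data alone, are the effect of the same one-carbon change on the cores of compound 2 and compound 3, and the effect of placing an amine or a carboxylic acid on the chain.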